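The source may hold more compounds than are shown below. What is called first, only, known or untested is meant among the compounds shown, and "the series" means these compounds.

Compound 1 `O=C(NC[C@H](NS(=O)(=O)c1cccs1)C(=O)O)c1ccc(N2CCC[C@H](NC3=NCCCN3)C2)cc1`: 99 nM
Compound 2 `O=C(NC[C@H](NS(=O)(=O)c1ccccc1)C(=O)O)c1ccc(N2CCC(NC3=NCCCN3)CC2)c(Cl)c1`: 90 nM

In a functional assay on a cell-free system (Platelet, plasma, Homo sapiens) for inhibition (a higher number here means a weaker inhibitor, a lower number a stronger inhibitor), compound 2 gives 90 nM and compound 1 gives 99 nM. The two numbers lie within the scatter of one another, so neither compound can be said to be the stronger inhibitor; compound 2 simply stands at one end of this pair of values, and the gap to compound 1 is too small to mean anything.

Compound 3 `COc1cc(C(=O)NC[C@H](NS(=O)(=O)c2ccccc2)C(=O)O)ccc1N1CCC(NC2=NCCCN2)CC1` is the next compound, and it differs from compound 2 in one place: methoxy in place of chloro on an aromatic carbon. For the measured compounds named here, no pair among the measured compounds shows what this exchange does in this assay, so there is no measured step to lean on. The change is small in size, and the expectation is a modest step, if any, toward a somewhat higher number, most likely not clearly beyond the scatter. Compound 3 is therefore expected to give about 130 nM, with a range from 45 nM to 400 nM. This estimate means a step of a 1.4-fold higher number from compound 2 to compound 3 (0.16 log units; within the scatter).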

Compound 3, half-maximal inhibitory concentration: 130 nM
For compound 3 middle estimate and measured number coincide at the digits printed; low and high end bracket the measured number.
By their numbers in this assay, from the lowest: compounds 2, 1 and 3 (each within the scatter of the next).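

For the compounds shown here, compounds 2 and 3 form the first measured pair that differs in one place, so they give the first direct reading of a change on this aromatic carbon, ortho to a large group and meta to a large group. In this assay, methoxy in place of chloro gives a step of a 1.4-fold higher number from compound 2 to compound 3 (0.16 log units; within the scatter), so the two compounds cannot be told apart in this assay, even though the entering group brings one more heavy atom and a hydrogen-bond acceptor that chloro lacks. Nothing measured here explains this outcome, and the reading stands only as an observation about this single pair.

What the compounds shown leave open is whether this position stays as undemanding for groups of a different kind, such as an amine, a nitrile or a carboxylic acid, or for a longer chain such as butoxy in place of methoxy. One exchange within the scatter also leaves open whether a plain hydrogen on this carbon would give a number in the same range as those of compound 2 and compound 3.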